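This account rests on a few compounds, and the source may have more. Where it says the series, first, only, none or still open, it means among the compounds named here.

Working notes on the chain series, read in a functional assay on brain (Rattus norvegicus, strain Wistar) for inhibition; a higher number here means a weaker inhibitor, a lower number a stronger inhibitor. Compound 1 (`CCCCc1ccc(-c2c(C)[nH]c(=O)n2C)cc1`) gives 10700 nM, compound 2 (`CCCCCc1ccc(-c2c(C)[nH]c(=O)n2C)cc1`) gives 5900 nM and compound 3 (`CCCCCCCc1ccc(-c2c(C)[nH]c(=O)n2C)cc1`) gives 8400 nM. Compound 3 cannot be separated from the other two on these numbers: a 1.3-fold lower number from compound 1 to compound 3 (0.11 log units; within the scatter) and a 1.4-fold higher number from compound 2 to compound 3 (0.15 log units; within the scatter) both lie within the scatter.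

Compound 4 (`CCCCCCCCc1ccc(-c2c(C)[nH]c(=O)n2C)cc1`) differs from compound 3 by methyl in place of hydrogen on a saturated chain carbon, seven bonds along the chain from an aromatic carbon, a methyl in place of hydrogen on a saturated chain carbon, seven bonds along the chain from an aromatic carbon. The nearest measured precedents are also chain extensions. One is a 1.8-fold lower number from compound 1 to compound 2 (0.26 log units; within the scatter), the same methyl in place of hydrogen but four bonds along the chain. The other is a 1.4-fold higher number from compound 2 to compound 3 (0.15 log units; within the scatter), with ethyl in place of hydrogen five bonds along the chain. Both stay within the scatter, and together they give no direction to carry forward. Within the data shown here, no measurement yet exists for a change seven bonds along the chain, so the range is kept wide.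

No step beyond the scatter is therefore expected in this assay, and the expected step is small: a 1.1-fold lower number from compound 3 to compound 4 (0.05 log units; within the scatter). Compound 4 is estimated at 7500 nM, with an expected range of 3500 nM to 16000 nM.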

Compound 4, half-maximal inhibitory concentration: 19400 nM
The estimate for compound 4 lay 2.6-fold (0.41 log units) below the measured number; measured number outside the range, above it.
By their numbers in this assay, from the lowest: compounds 2, 3, 1 and 4 (each within the scatter of the next, the first and the last beyond it).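

In this assay the chain series now shows its first steps beyond the scatter, both towards a higher number: a 2.3-fold higher number from compound 3 to compound 4 (0.36 log units; beyond the scatter) for methyl in place of hydrogen seven bonds along the chain, and a 3.3-fold higher number from compound 2 to compound 4 (0.52 log units; beyond the scatter) for propyl in place of hydrogen five bonds along the chain. The same methyl replacement therefore does not read alike at the two places along the chain: the same change on two cores in this assay, a 1.8-fold lower number (0.26 log units; within the scatter) from compound 1 to compound 2 and a 2.3-fold higher number (0.36 log units; beyond the scatter) from compound 3 to compound 4, 4.2-fold (0.62 log units) apart, beyond the scatter of two such steps. With a 1.8-fold higher number from compound 1 to compound 4 (0.26 log units; within the scatter) still inside the scatter, compound 4 separates from compound 2 and compound 3 but not from compound 1, and the longer extension likewise depends on the chain it starts from: the same change on two cores in this assay, a 1.3-fold lower number (0.11 log units; within the scatter) from compound 1 to compound 3 and a 3.3-fold higher number (0.52 log units; beyond the scatter) from compound 2 to compound 4, 4.2-fold (0.62 log units) apart, beyond the scatter of two such steps.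

On these data alone, whether a longer chain such as decyl continues this rise, or whether an amine or a carboxylic acid carried on the chain changes it, stays open. Compound 1, compound 2 and compound 3 also remain within the scatter of each other, so the shape of the dependence on chain length up to compound 3 is unresolved, and a single higher number at compound 4 does not yet define a trend.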